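The source may hold more compounds than are shown below. What is called first, only, known or untested is meant among the compounds shown, and "the series" means these compounds.

Compound 1 `Cc1nnc(SCC(=O)c2ccc(Cl)cc2)n1N1C(=O)c2ccccc2C1=O` gives > 200000 nM in a functional assay on MKN-45 cells (Homo sapiens) for cytotoxicity, read by MTT assay, with a stated time of 48 h (on this read-out higher numbers stand for weaker inhibition and lower numbers for stronger inhibition), which is a limit of the assay rather than a number.
Compound 2 `Cc1ccc(C(=O)CSc2nnc(C)n2N2C(=O)c3ccccc3C2=O)cc1` gives > 200000 nM in this assay, again only a limit.
Compound 3 `CCc1nnc(SCC(=O)c2ccc(Cl)cc2)n1N1C(=O)c2ccccc2C1=O` gives > 200000 nM in this assay, also a limit.

From compound 1 to compound 2 the change is methyl in place of chloro on an aromatic carbon, and it gave a step that the two limits leave unreadable from compound 1 to compound 2. The cores of compound 1 and compound 3 differ by methyl in place of hydrogen on a saturated chain carbon bound to an aromatic carbon, with a step that the two limits leave unreadable from compound 1 to compound 3. Compound 4 `CCc1nnc(SCC(=O)c2ccc(C)cc2)n1N1C(=O)c2ccccc2C1=O` has not yet been measured; it carries the same change as before, (methyl in place of chloro on an aromatic carbon), at the same place. Because the limit of > 200000 nM in this assay, at which 3 of the 3 values shown sit, holds every value shown, the step that the limit leaves unreadable from compound 3 to compound 4 is expected to be unreadable as well. Compound 4 is therefore expected to sit near 300000 nM, somewhere between 150000 nM and 1000000 nM, most likely reported as a limit once more.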

Compound 4, half-maximal inhibitory concentration: > 200000 nM
Compound 4 gave a limit, no number; the forecaster's own chance of this, stated with the estimate: 85%; the middle value lies beyond the limit too.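

No step among compound 1, compound 2, compound 3 and compound 4 can be read, because each gives only a limit of the assay: the limit of > 200000 nM in this assay, at which 4 of the 4 values shown sit.

The compounds shown leave open how 4-chlorophenyl and 4-methylphenyl truly compare in this assay, since no measured number exists for either.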